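Notes on the dithiocarbamate series: methyl removal

The compounds below may be only part of what the source reports. "The series", "measured", "known", "first", "only" and "open" are said of these compounds alone.

Compound 1 `O=c1c(CSC(=S)N2CCCC2)coc2ccccc12` gives 2300 nM in a functional assay on SW480 cells (Homo sapiens) for antiproliferative activity, read by MTT assay, with a stated time of 72 h; on this read-out higher numbers stand for weaker inhibition and lower numbers for stronger inhibition. Compound 2 `Cc1ccc2c(=O)c(CSC(=S)N(C(C)C)C(C)C)coc2c1` is known only as a limit of the assay, reported as > 25000 nM in this assay. Its standing among the numbers shown is therefore a bound rather than a number, as recorded in the limit of > 25000 nM in this assay, at which 1 of the 2 values shown sits. Compound 3 `CC(C)N(C(=S)SCc1coc2ccccc2c1=O)C(C)C` has not yet been measured in this assay. It differs from compound 2 by hydrogen in place of methyl on an aromatic carbon. Among the compounds with values here, no step between measured compounds covers this change, so nothing in the set fixes its size or direction. Compound 2 already sits at a limit. Compound 3 is expected to stay weak, with an expected step of an at least 1.2-fold lower number from compound 2 to compound 3 (0.09 log units; that floor lies within the scatter) that need not exceed the scatter. For compound 3 the estimate in this assay is 20000 nM, within 6000 nM to 60000 nM.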

Compound 3, half-maximal inhibitory concentration: 6800 nM
Compound 3: middle estimate off by 2.9-fold (0.47 log units), on the high side; the measured number falls inside the stated range.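

Hydrogen in place of methyl on an aromatic carbon gives an at least 3.6-fold lower number from compound 2 to compound 3 (0.56 log units; beyond the scatter) in this assay, so this position on the shared core has a visible bearing on the read-out. The size of that step has only a floor, since compound 2 is a limit of the assay and not a number: the limit of > 25000 nM in this assay, at which 1 of the 3 values shown sits.

With the methyl gone, the amine end can also be compared in one place: diisopropylamino in place of pyrrolidin-1-yl on a thiocarbonyl carbon gives a 3.0-fold higher number from compound 1 to compound 3 (0.47 log units; beyond the scatter), which places pyrrolidin-1-yl ahead of diisopropylamino on this core.

As far as these compounds go, the methyl step is read only alongside diisopropylamino, so its size alongside pyrrolidin-1-yl remains open. Also open, from the compounds shown here alone, is how a chlorine, a methoxy group or a longer chain such as ethyl would behave on the same aromatic carbon.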